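Methyl Placement on the Shared Core and Cytotoxicity

This account rests on a few compounds, and the source may have more. Where it says the series, first, only, none or still open, it means among the compounds named here.

Measured so far:
compound 1, `COC(=O)c1sc2cc(C)ccc2c1Nc1cc(OC)c(OC)c(OC)c1`: 1.2 nM
compound 2, `COC(=O)c1sc2ccccc2c1Nc1cc(OC)c(OC)c(OC)c1`: 795 nM
compound 3, `COC(=O)c1sc2ccc(C)cc2c1Nc1cc(OC)c(OC)c(OC)c1`: 540 nM

In a functional assay on MCF7 cells (Homo sapiens) for cytotoxicity, read by MTT assay, with a stated time of 72 h (a lower number here means a stronger inhibitor, a higher number a weaker inhibitor), compound 2 gives the highest number of the three. Compound 3 sits close, a step that stays within the scatter, while compound 1 lies far away, a step well beyond it. The unmeasured compound 4 is `COC(=O)c1sc2c(C)cccc2c1Nc1cc(OC)c(OC)c(OC)c1`, which differs from compound 2 by methyl in place of hydrogen on an aromatic carbon, where the methyl enters on an aromatic carbon of a six-membered ring of carbon only, part of a fused system of two rings.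

Among the compounds with values here, two steps bear on this change. The step of a 660-fold higher number from compound 1 to compound 2 (2.82 log units; beyond the scatter) shows that a methyl on one aromatic carbon of the shared core goes with a very large difference, while the step of a 1.5-fold lower number from compound 2 to compound 3 (0.17 log units; within the scatter) shows that a methyl on another such carbon changes nothing beyond the scatter. Within the data shown here, the effect therefore depends on where the methyl enters, and the position in compound 4 has no direct precedent. The step expected here is a 2.7-fold lower number from compound 2 to compound 4 (0.42 log units; beyond the scatter), and this estimated step is of uncertain size. For compound 4 the expected value in this assay is 300 nM, with a range from 15 nM to 1500 nM.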

Compound 4, half-maximal inhibitory concentration: 4550 nM
Compound 4: middle estimate off by 15-fold (1.18 log units), on the low side; measured number above the stated range.
By their numbers in this assay, from the lowest: compound 1; then compounds 3 and 2 (each within the scatter of the next); then compound 4.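

In this assay, methyl in place of hydrogen on this aromatic carbon gives a 5.7-fold higher number from compound 2 to compound 4 (0.76 log units; beyond the scatter) and so makes the inhibitor weaker, a direction that neither earlier methyl placement showed. The same one-group change on the shared core now has three outcomes: a far lower number in compound 1, no shift beyond the scatter in compound 3, and a higher number in compound 4, so position alone can decide whether a methyl helps, does nothing or harms. No measurement here accounts for these differences.

From the compounds shown here alone, whether the higher number at this position is particular to methyl remains open. An ethyl chain, a chlorine atom or an amine on the same carbon, and on the carbon that carries the methyl in compound 1, would test how far each position tolerates other groups.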